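The compounds below may be only part of what the source reports. "The series", "measured", "known", "first", "only" and "open" are said of these compounds alone.

Compound 1 `C=C1C(=O)[C@@]23C(=O)OC[C@]4([C@@H](OC(C)=O)CCC(C)(C)[C@H]4C=O)[C@@H]2CC[C@H]1[C@H]3OC(C)=O`: 1740 nM
Compound 2 `C=C1C(=O)[C@@]23C(=O)OC[C@]4([C@@H](OC(C)=O)CCC(C)(C)[C@H]4C=O)[C@@H]2CC[C@H]1[C@H]3OC(=O)c1ccc([N+](=O)[O-])cc1`: 1140 nM

Both numbers come from a functional assay on K562 cells (Homo sapiens) for inhibition, read by MTT assay; on this read-out higher numbers stand for weaker inhibition and lower numbers for stronger inhibition. Among the measured compounds shown here, compound 2 gives the lowest of the two numbers, yet the single measured step, a 1.5-fold lower number from compound 1 to compound 2 (0.18 log units; within the scatter), stays within the scatter, so neither compound can be called more potent than the other. Compound 3 `C=C1C(=O)[C@@]23C(=O)OC[C@]4([C@@H](OC(C)=O)CCC(C)(C)[C@H]4C=O)[C@@H]2CC[C@H]1[C@H]3OC(=O)c1ccc(Cl)cc1` differs from compound 2 by chloro in place of nitro on an aromatic carbon, placed on an aromatic carbon of a six-membered aromatic ring of carbon only. For the measured compounds named here, no measured step exchanges one group for another at that place; the measured step concerns a different part of the molecule and was itself within the scatter. He therefore expects no step beyond the scatter, a 1.1-fold higher number from compound 2 to compound 3 (0.02 log units; within the scatter). His estimate for compound 3 is 1200 nM, expected to fall between 500 nM and 3000 nM.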

Compound 3, half-maximal inhibitory concentration: 870 nM
The estimate for compound 3 lay 1.4-fold (0.14 log units) above the measured number, within the range that was stated.
By their numbers in this assay, from the lowest: compounds 3, 2 and 1 (each within the scatter of the next).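

In this assay the exchange of nitro for chloro on an aromatic carbon, para to a large group, gives a 1.3-fold lower number from compound 2 to compound 3 (0.12 log units; within the scatter) and so does not separate the two groups at this place. The 4-chlorophenyl group in place of methyl on the carbonyl carbon gives a 2.0-fold lower number from compound 1 to compound 3 (0.30 log units; within the scatter) and also stays within the scatter, so this second aromatic group does not separate from methyl either. Nothing available explains these small steps. Going by these compounds, whether an amine or a carboxylic acid on that aromatic carbon would give a step beyond the scatter remains open. So does whether a longer chain in place of the aromatic group on the carbonyl carbon would do so.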